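A few compounds are considered here, and "the series" means these few. Any claim that something is new, unique, unknown or untested is made for them only; others in the source may bear on it.

Working notes on a series built on the core of compound 3 `C/C=C/C(=O)NCCOc1ccc(Oc2c(-c3ccc(F)cc3)sc3cc(O)ccc23)cc1`, with variation confined to the group on an oxygen on an aromatic ring. In a functional assay on Ishikawa cells (Homo sapiens) for antiproliferative activity, read by CCK-8 assay, with a stated time of 48 h (a higher number here means a weaker inhibitor, a lower number a stronger inhibitor), compound 3 gives 12400 nM. Compound 2 `CNC(=O)/C=C/CNCCOc1ccc(Oc2c(-c3ccc(F)cc3)sc3cc(O)ccc23)cc1` gives 15500 nM in this assay. Compound 1 `C=C(C)C(=O)NCCOc1ccc(Oc2c(-c3ccc(F)cc3)sc3cc(O)ccc23)cc1` reaches only the limit of > 25000 nM in this assay. Compound 3 thus holds the lower of the two numbers reported, while the third value is a limit (the limit of > 25000 nM in this assay, at which 1 of the 3 values shown sits). The nearest number is separated by a 1.3-fold lower number from compound 2 to compound 3 (0.10 log units; within the scatter), which is within the scatter, and the other measured step, an at least 2.0-fold lower number from compound 1 to compound 3 (0.30 log units; that floor lies within the scatter), has a floor that also lies within the scatter.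

Compound 4 `C=CC(=O)N1CC(Oc2ccc(Oc3c(-c4ccc(F)cc4)sc4cc(O)ccc34)cc2)C1` is not yet measured in this assay. The change is 1-(vinylcarbonyl)azetidin-3-yl in place of 2-(((prop-1-en-1-yl)carbonyl)amino)ethyl on an oxygen on an aromatic ring. What leaves is 2-(((prop-1-en-1-yl)carbonyl)amino)ethyl, what enters is 1-(vinylcarbonyl)azetidin-3-yl, on an oxygen on an aromatic ring whose other neighbour is an aromatic carbon. Both measured steps rework the same group at the same oxygen, and neither is reported as moving the number beyond the scatter. The expected step is therefore a 1.1-fold lower number from compound 3 to compound 4 (0.05 log units; within the scatter), nothing beyond the scatter in either direction. Compound 4 is estimated at 11000 nM, between 4000 nM and 30000 nM.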

Compound 4, half-maximal inhibitory concentration: 12300 nM
Beside the measured number, compound 4's estimate is 1.1-fold (0.05 log units) below it, within the range that was stated.
By their numbers in this assay, from the lowest: compounds 4, 3 and 2 (each within the scatter of the next). At a limit, above all of these: compound 1.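

At the oxygen on an aromatic ring, 1-(vinylcarbonyl)azetidin-3-yl brings a four-membered non-aromatic ring and no hydrogen-bond donor, yet in this assay the exchange for the open 2-(((prop-1-en-1-yl)carbonyl)amino)ethyl chain, with the same count of heavy atoms, gives no separation beyond the scatter (a 1.0-fold lower number from compound 3 to compound 4 (0.00 log units; within the scatter)). Among the compounds shown here, the earlier compounds reworked only the open chain, so this is the first sign that, within these compounds, the ring form and the open form cannot be told apart in this assay, and the comparison with the amine-linked chain reads the same way (a 1.3-fold lower number from compound 2 to compound 4 (0.10 log units; within the scatter)), while the remaining step has a floor within the scatter (an at least 2.0-fold lower number from compound 1 to compound 4 (0.30 log units; that floor lies within the scatter)). Compound 1 is a limit and not a number: the limit of > 25000 nM in this assay, at which 1 of the 4 values shown sits.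

The compounds shown leave open whether any group at this oxygen separates beyond the scatter, since a piperidine or pyrrolidine ring, a longer chain or a plain hydroxyethyl group does not appear among them. Also open, on these data alone, is what a saturated propanoyl group would give in place of the vinylcarbonyl on the azetidine nitrogen.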